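Notes on compound 4: phenyl for acetamidomethyl on the amine side chain

The compounds below may be only part of what the source reports. "The series", "measured", "known", "first", "only" and "open" are said of these compounds alone.

Compound 3 `COc1cc(Oc2cccc(Nc3ccccc3)c2)cc(OC)c1CNCCNC(C)=O` carries the shared core with a 2-acetamidoethyl group on the amine nitrogen. Among the measured compounds shown here, in a functional assay on HT-29 cells (Homo sapiens) for inhibition, read by MTT assay, with a stated time of 72 h (a lower number here means a stronger inhibitor, a higher number a weaker inhibitor), compound 3 gives 3960 nM, the second highest of the three numbers measured so far. Compound 1 `COc1cc(Oc2cccc(Nc3ccccc3)c2)cc(OC)c1CNCc1ccc(Br)cc1` gives 3060 nM in this assay, and compound 2 `COc1cc(Oc2cccc(Nc3ccccc3)c2)cc(OC)c1CNC1CC1` gives 12300 nM. The measured steps read: a 1.3-fold higher number from compound 1 to compound 3 (0.11 log units; within the scatter); a 4.0-fold higher number from compound 1 to compound 2 (0.60 log units; beyond the scatter); a 3.1-fold lower number from compound 2 to compound 3 (0.49 log units; beyond the scatter). Only the cyclopropyl compound 2 stands apart beyond the scatter; compound 1 and compound 3 sit within the scatter of each other.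

Compound 4 `COc1cc(Oc2cccc(Nc3ccccc3)c2)cc(OC)c1CNCc1ccccc1` is the next member. The change from compound 3 is phenyl in place of acetamidomethyl on a saturated chain carbon bound to an amine nitrogen. The step that bears on it is a 1.3-fold higher number from compound 1 to compound 3 (0.11 log units; within the scatter), which swaps the same acetamidomethyl against 4-bromophenyl and stays within the scatter. The steps to and from compound 2 concern cyclopropyl and do not touch this exchange. Compound 4 is therefore expected to show a step of a 1.1-fold lower number from compound 3 to compound 4 (0.05 log units; within the scatter), not beyond the scatter, because a 1.3-fold higher number from compound 1 to compound 3 (0.11 log units; within the scatter) was itself within it. Compound 4 is estimated at 3500 nM in this assay, with a range from 1500 nM to 8000 nM.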

Compound 4, half-maximal inhibitory concentration: 3340 nM
The estimate for compound 4 lay 1.0-fold (0.02 log units) above the measured number, and the stated range covers the measured number.
By their numbers in this assay, from the lowest: compounds 1, 4 and 3 (each within the scatter of the next); then compound 2.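

In this assay, phenyl in place of acetamidomethyl on a saturated chain carbon bound to an amine nitrogen gives a 1.2-fold lower number from compound 3 to compound 4 (0.07 log units; within the scatter), so this exchange of an open amide chain for an aromatic ring produces no readable change. Hydrogen in place of bromo on an aromatic carbon gives a 1.1-fold higher number from compound 1 to compound 4 (0.04 log units; within the scatter), so the bromo group is not required here, while benzyl in place of cyclopropyl on an amine nitrogen gives a 3.7-fold lower number from compound 2 to compound 4 (0.57 log units; beyond the scatter), which leaves compound 2 alone beyond the scatter of the other three. No measurement shown here gives a reason for these steps.

On these data alone, whether a carboxylic acid, a morpholine ring or a longer chain on the amine nitrogen would move the number beyond that scatter remains open. The same holds for a methoxy or a nitrile in place of the bromo group.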